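One Ring Swap in a Quiet Series

The source may hold more compounds than are shown below. What is called first, only, known or untested is meant among the compounds shown, and "the series" means these compounds.

Of the compounds shown here, three sharing one core have been tested in a functional assay on HepG2 cells (Homo sapiens) for inhibition, read by MTT assay; a lower number here means a stronger inhibitor, a higher number a weaker inhibitor. Compound 1 `COc1cc2ncnc(Nc3ccc(NC(=O)c4cccc(C)c4)cc3)c2cc1OC` gives 7500 nM, compound 2 `COc1cc2ncnc(Nc3ccc(NC(=O)c4ccccc4F)cc3)c2cc1OC` gives 13000 nM and compound 3 `COc1cc2ncnc(Nc3ccc(NC(=O)c4cccc(Cl)c4)cc3)c2cc1OC` gives 12000 nM. Compound 2 lies within the scatter of both others, so these three cannot be ranked.

Compound 4 `COc1cc2ncnc(Nc3ccc(NC(=O)c4ccc(Cl)cc4)cc3)c2cc1OC`, not yet measured, differs from compound 2 only in the group on the carbonyl carbon: 4-chlorophenyl in place of 2-fluorophenyl on a carbonyl carbon. Here, 4-chlorophenyl takes the place of 2-fluorophenyl on a carbonyl carbon whose other neighbour is an amide-type nitrogen.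

The closest evidence is a 1.1-fold lower number from compound 2 to compound 3 (0.03 log units; within the scatter), where 3-chlorophenyl stands in place of the same 2-fluorophenyl. The other two measured steps are a 1.7-fold higher number from compound 1 to compound 2 (0.24 log units; within the scatter) and a 1.6-fold higher number from compound 1 to compound 3 (0.20 log units; within the scatter). For the measured compounds named here, every exchange of these groups has so far stayed inside the scatter, although no tested compound carries a 4-chlorophenyl group, so the forecast reaches beyond the data.

On the strength of compound 3 at 12000 nM, no step beyond the scatter is expected in this assay, and neither direction is favoured. The expected step is a 1.2-fold lower number from compound 2 to compound 4 (0.07 log units; within the scatter). The estimated value for compound 4 is 11000 nM, within an expected range of 5500 nM to 22000 nM.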

Compound 4, half-maximal inhibitory concentration: 28000 nM
For compound 4 the middle estimate is 2.5-fold (0.41 log units) below the measured one; measured number above the stated range.
By their numbers in this assay, from the lowest: compounds 1, 3 and 2 (each within the scatter of the next); then compound 4.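

For the compounds shown here, the group on the carbonyl carbon had looked free to vary in this assay, but 4-chlorophenyl is the one group of the four whose exchange goes beyond the scatter, with a 2.2-fold higher number from compound 2 to compound 4 (0.33 log units; beyond the scatter) and a 3.7-fold higher number from compound 1 to compound 4 (0.57 log units; beyond the scatter). The most telling step is a 2.3-fold higher number from compound 3 to compound 4 (0.37 log units; beyond the scatter), as 3-chlorophenyl and 4-chlorophenyl differ only in where the chlorine sits, so the presence of chlorine alone does not set the number here. All three steps point the same way and make compound 4 the weakest inhibitor of the four, although each step is only modest in size.

Nothing among the data shown explains why this one exchange raises the number.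
On these data alone, it also remains open whether the rise belongs to chlorine in particular or would also appear with other groups of the same naming pattern, such as 4-fluorophenyl, 4-methylphenyl or 4-methoxyphenyl, and whether a larger change on the ring, such as an added amine or carboxylic acid, would move the number further.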